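The source may hold more compounds than are shown below. What is called first, only, known or untested is meant among the compounds shown, and "the series" means these compounds.

Measured so far:
- compound 1, `CC1CCN(C2CCN(S(=O)(=O)c3cccc(-c4ccc(Cl)cc4)c3)CC2)CC1`: 15 nM
- compound 2, `Cc1cc(C)c(S(=O)(=O)N2CCC(N3CCC(C)CC3)CC2)c(C)c1`: 0.03 nM
- compound 3, `Cc1cc(C)c(S(=O)(=O)N2CCN(C3CCN(C)CC3)CC2)c(C)c1`: 426 nM

In a functional assay on DLD-1 cells (Homo sapiens) for antiproliferative activity, read by CellTiter-Glo, with a stated time of 72 h (on this read-out lower numbers stand for stronger inhibition and higher numbers for weaker inhibition), compound 1 gives 15 nM and sits second highest of the three numbers. Its nearest neighbour is compound 3, whose 426 nM is higher and beyond the scatter; compound 2, with 0.03 nM, lies far lower, also beyond the scatter. No pair among these differs in a single place, so no isolated step is available to read across.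

Compound 4, `CC1CCN(C2CCN(S(=O)(=O)c3cccc(Cl)c3)CC2)CC1`, is the next compound for this assay. It differs from compound 1 in one place: chloro in place of 4-chlorophenyl on an aromatic carbon. The aromatic part shrinks to a single ring with a single chloro, while the core is kept. The measured compounds give no direct guide for a change of this kind; compound 2 shows that a single ring can carry very strong inhibition, but compound 2 also differs from compound 1 in its substitution pattern, so it cannot be read as a step.

The expectation for compound 4 is a modest move toward a higher number, a 4.0-fold higher number from compound 1 to compound 4 (0.60 log units; beyond the scatter), beyond the scatter but not large. Compound 4 is estimated at 60 nM, with a range of 8 nM to 500 nM.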

Compound 4, half-maximal inhibitory concentration: > 5000 nM
Compound 4: only a limit was reported; the forecaster's own chance of this, stated with the estimate: 5%; middle value at least 83-fold (1.92 log units) away from the limit.
By their numbers in this assay, from the lowest: compound 2; then compound 1; then compound 3. At a limit, above all of these: compound 4.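

In this assay compound 4 gives > 5000 nM, which is a limit of the assay and not a number. Chloro in place of 4-chlorophenyl on an aromatic carbon, meta to a large group, gives an at least 330-fold higher number from compound 1 to compound 4 (2.52 log units; beyond the scatter), a large step beyond the scatter. This first single-place pair in the series shows that, with the core kept, chloro alone at this position does not retain the inhibition seen with 4-chlorophenyl in compound 1.

The compounds shown leave open whether the inhibition depends on the outer ring as such or on the chlorine it carries. An unsubstituted phenyl, a pyridine ring or a methoxy group at this position would help separate these readings.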